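The source may hold more compounds than are shown below. What is called first, only, known or untested is meant among the compounds shown, and "the series" means these compounds.

In an ADME assay on MDBK cells (Bos taurus) for cytotoxicity, read by MTT assay, with a stated time of 96 h (a higher number here means that more compound is tolerated, a lower number that less compound is tolerated), compound 1 `FC(F)(F)c1cccc(NC(=S)Nc2ccccc2)c1` gives 49000 nM as its half-maximal cytotoxic concentration. Compound 2 `CC(=O)NC(=S)Nc1cccc(C(F)(F)F)c1` reads > 100000 nM in this assay and this is a limit of the assay, not a number. Compound 2 therefore stands only at the limit of > 100000 nM in this assay, at which 1 of the 2 values shown sits, and offers no exact starting point for the next step.

Going by the values given here, the one measured step is an at least 2.0-fold higher number from compound 1 to compound 2 (0.30 log units; that floor lies within the scatter) and it came with acetyl in place of phenyl on an amide-type nitrogen. Compound 3 `FC(F)(F)c1cccc(NC(=S)NCc2ccco2)c1` differs from compound 2 at that nitrogen, with (furan-2-yl)methyl in place of acetyl on an amide-type nitrogen and so carries an aromatic ring there, as compound 1 does. Compound 1, with phenyl on this nitrogen, stands at 49000 nM and that value anchors the expectation. A single step is thin guidance, so a modest move to a lower number is expected, and another limit reading remains quite possible. The expected change is an at least 1.5-fold lower number from compound 2 to compound 3 (0.18 log units; that floor lies within the scatter) on these estimates. For compound 3 the estimate is 65000 nM with an expected range from 25000 nM to 100000 nM in this assay for now.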

Compound 3, half-maximal cytotoxic concentration: > 100000 nM
Compound 3 ended at the assay's limit; the forecaster's own chance of this, stated with the estimate: 40%; at least 1.5-fold (0.18 log units) between middle value and limit.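

In this assay, the step of an at least 2.0-fold higher number from compound 1 to compound 3 (0.30 log units; that floor lies within the scatter) shows that carrying an aromatic ring on the amide-type nitrogen does not by itself give a reading like that of compound 1, although the printed floor of this step gives no firm separation between the two compounds. Compound 2 and compound 3 both read as limits of the assay, not as numbers, and the step between them cannot be read. Acetyl and (furan-2-yl)methyl on this nitrogen therefore cannot be ranked, and the series now gives mostly limit readings: the limit of > 100000 nM in this assay, at which 2 of the 3 values shown sit.

Going by these compounds alone, compound 1, at 49000 nM, remains the only exact value, so the true size of any change at this nitrogen is still unknown, as is whether replacing phenyl with (furan-2-yl)methyl makes a difference beyond the scatter. As far as these compounds go, what a cyclohexyl ring, a longer alkyl chain or a carboxylic acid on the same nitrogen would give in this assay also stays open.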